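The compounds below may be only part of what the source reports. "The series", "measured", "known", "first", "only" and "open" are said of these compounds alone.

Measured so far:
Compound 1 `COc1cc(OC)c(OC)cc1/C=C/COC(=O)/C=C/c1ccc(OC)c(OC)c1`: 100%
Compound 2 `COc1cc(OC)c(OC)cc1/C=C/COC(=O)/C=C/c1cc(OC)c(OC)c(OC)c1OC`: 100%

In a functional assay on the whole organism (strain Kunming) with Mus musculus as the target, with a stated time of 0.5 h, at a dose of 100 mg/kg by the intraperitoneal route (a higher number here means a weaker effect of the compound at the dose given, a lower number a stronger effect), compound 1 gives 100%, and compound 2 gives 100%. The two values are level, so neither can be called stronger or weaker than the other.

Compound 3 `COc1cc(OC)c(OC)cc1/C=C/COC(=O)/C=C/c1ccc(F)cc1` differs from compound 1 in one place: 4-fluorophenyl in place of 3,4-dimethoxyphenyl on a double-bonded chain carbon bound to a double-bonded chain carbon. For the measured compounds named here, no measured pair shows what such a change does here, so nothing firm is known about its size or direction. Going by the values given here, with only two level values to go on, the step from compound 1 to compound 3 is expected to be small, a number 5 percentage points lower from compound 1 to compound 3 (within the scatter), within the scatter or at most slightly toward a stronger effect. Compound 3 is therefore estimated at 95%, in a range from 70% to 100%.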

Compound 3, a percentage reported as activity, at one dose (the size of the read-out at that dose, not a potency): 100%
Estimate against measurement, compound 3: 5 percentage points below; the range from low to high includes it.
By their numbers in this assay, from the lowest: compounds 1, 2 and 3 (each within the scatter of the next).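

In this assay, putting 4-fluorophenyl in place of 3,4-dimethoxyphenyl on a double-bonded chain carbon bound to a double-bonded chain carbon gives no change at the digits printed from compound 1 to compound 3 (within the scatter). So this position can lose both methoxy groups and carry a fluorine with no visible shift in the read-out, a flat result that goes beyond the earlier pair, which differed only in how many methoxy groups the ring carried. Nothing at hand accounts for this flat result.

Still open, going by these compounds, is whether any group at this position can lower the number at all. An amine or a carboxylic acid on this ring, or a longer chain in place of the double-bonded chain, would test that.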